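This account rests on a few compounds, and the source may have more. Where it says the series, first, only, none or still open, it means among the compounds named here.

Compound 1 `CCCCC(=O)N(Cc1ccc(OC)c(O)c1)c1cc(OC)c(OC)c(OC)c1` gives 170 nM
Compound 2 `C/C=C/C(=O)N(Cc1cc(OC)c(OC)c(OC)c1)c1ccc(OC)c(O)c1` gives 8450 nM
Compound 3 `COc1ccc(CNc2cc(OC)c(OC)c(OC)c2)cc1Br` gives 48100 nM

These three numbers come from a functional assay on HCT-116 cells (Homo sapiens) for inhibition, read by MTT assay, with a stated time of 48 h (a higher number here means a weaker inhibitor, a lower number a stronger inhibitor), and span a wide range. Compound 1 holds the lowest of them, and the gaps up to compound 2 and compound 3 both lie beyond the scatter of repeated measurements, so it is the strongest inhibitor of the three.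

Still unmeasured is compound 4 `C#CC(=O)N(Cc1ccc(OC)c(O)c1)c1cc(OC)c(OC)c(OC)c1`, which keeps the core of compound 1 and changes one group: ethynyl in place of butyl on a carbonyl carbon.

Among the measured compounds shown here, no two measured compounds differ in just one place, so the data offer no direct guide to this swap. Only a general expectation remains. Compound 1 gives 170 nM, the lowest number of the three, and so has more room to lose than to gain. In this assay a step towards a higher number, meaning a weaker inhibitor, is therefore expected. It should be of moderate size and probably beyond the scatter, although a step within the scatter cannot be ruled out. The expected change is a 5.9-fold higher number from compound 1 to compound 4 (0.77 log units; beyond the scatter), and it remains only an estimate. For compound 4 the estimated value is 1000 nM, with an expected range from 150 nM to 8000 nM.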

Compound 4, half-maximal inhibitory concentration: 310 nM
Estimate against measurement, compound 4: 3.2-fold (0.51 log units) above, within the range that was stated.
By their numbers in this assay, from the lowest: compounds 1 and 4 (each within the scatter of the next); then compound 2; then compound 3.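

Swapping butyl for ethynyl on a carbonyl carbon gives a 1.8-fold higher number from compound 1 to compound 4 (0.26 log units; within the scatter) in this assay and is the first change in this series that can be read on its own, as no earlier pair of measured compounds differed in just one place. The group on this carbon can thus go from butyl, with 4 heavy atoms, to ethynyl, with 2 heavy atoms and a triple bond, with no difference beyond the usual scatter, so compound 1 and compound 4 cannot be told apart by this measurement. No measurement shown bears on what lies behind this result.

Going by these compounds, two groups are still a small sample of what this carbon could carry, and it remains open whether a longer chain such as octyl, an amine or a carboxylic acid in the same place would keep the number in this range. On these data alone, it is also open whether ethynyl would match butyl in the same way on any other core.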